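The source may hold more compounds than are shown below. What is called first, only, known or untested is meant among the compounds shown, and "the series" means these compounds.

Measured compounds:
compound 1, `CN1CCN(CCCCCCn2c3c(c4ccccc42)C(=O)c2c[n+]([O-])c4ccccc4c2C3=O)CC1`, 2400 nM
compound 2, `CN1CCN(CCCCCn2c3c(c4ccccc42)C(=O)c2c[n+]([O-])c4ccccc4c2C3=O)CC1`, 2270 nM
compound 3, `O=C1c2c[n+]([O-])c3ccccc3c2C(=O)c2c1c1ccccc1n2Cc1cn([C@H]2C[C@H](O)[C@@H](CO)O2)nn1`, 580 nM

All three were tested in a functional assay on MDA-MB-231 cells (Homo sapiens) for cytotoxicity, read by MTT assay, with a stated time of 72 h; on this read-out higher numbers stand for weaker inhibition and lower numbers for stronger inhibition. Compound 3 has the lowest number of the three, and its gaps to compound 2 and to compound 1 both lie beyond the usual scatter, so on these numbers compound 3 is the strongest inhibitor of the set. Within the data shown here, the only measured step, a 1.1-fold lower number from compound 1 to compound 2 (0.02 log units; within the scatter), concerns the length of the saturated chain on the shared core and is within the scatter; it does not touch the group that changes here.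

Compound 4, `O=C1c2c[n+]([O-])c3ccccc3c2C(=O)c2c1c1ccccc1n2Cc1cn(C[C@@H](O)CO)nn1`, differs from compound 3 in one place: 2,3-dihydroxypropyl in place of 4-hydroxy-5-(hydroxymethyl)oxolan-2-yl on an aromatic nitrogen. Among the measured compounds shown here, no measured pair shows what this change does, so there is no direct guide. With nothing to point either way, compound 4 is expected to stay near compound 3, with the step of a 1.6-fold higher number from compound 3 to compound 4 (0.19 log units; within the scatter) estimated as small, most likely no more than the scatter, and leaning towards a slightly higher number. Compound 4 is therefore estimated at 900 nM, within a range from 350 nM to 2500 nM.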

Compound 4, half-maximal inhibitory concentration: 670 nM
For compound 4 the middle estimate is 1.3-fold (0.13 log units) above the measured one; the measured number falls inside the stated range.
By their numbers in this assay, from the lowest: compounds 3 and 4 (each within the scatter of the next); then compounds 2 and 1 (each within the scatter of the next).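

In this assay, replacing 4-hydroxy-5-(hydroxymethyl)oxolan-2-yl with 2,3-dihydroxypropyl on the aromatic nitrogen gives a 1.2-fold higher number from compound 3 to compound 4 (0.06 log units; within the scatter), so at this position the open chain with no ring matches the ring-bearing group within the scatter. The 1-(2,3-dihydroxypropyl)-1H-1,2,3-triazol-4-yl group also stays apart from the methylpiperazine chains, with a 3.4-fold lower number from compound 2 to compound 4 (0.53 log units; beyond the scatter) and a 3.6-fold lower number from compound 1 to compound 4 (0.55 log units; beyond the scatter), both beyond the scatter. No measured evidence bearing on these results is available to explain them.

As far as these compounds go, what a plain propyl chain, an amine or a carboxylic acid would do on this aromatic nitrogen remains open, as does whether the hydroxyl groups matter there at all. The mirror-image form of the 2,3-dihydroxypropyl group also leaves open whether its defined stereocentre counts.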